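The compounds below may be only part of what the source reports. "The series", "measured", "known", "first", "only" and "open" are said of these compounds alone.

Series notes. Compound 1 `Nc1nc(O)c2c(n1)n(C1OC(CO)[C@@H](O)[C@H]1O)c(=O)n2C/C=C/c1ccccc1` carries 2-phenylethenyl on a saturated chain carbon bound to an aromatic nitrogen, compound 2 `N#Cc1cccc(Cn2c(=O)n(C3OC(CO)[C@@H](O)[C@H]3O)c3nc(N)nc(O)c32)c1` carries 3-cyanophenyl at that place, and compound 3 `N#Cc1ccc(Cn2c(=O)n(C3OC(CO)[C@@H](O)[C@H]3O)c3nc(N)nc(O)c32)cc1` carries 4-cyanophenyl there. In a functional assay on the whole organism (B cells) with Mus musculus as the target (a higher number here means a larger maximal response, a lower number a smaller maximal response), compound 1 gives 73%, compound 2 gives 16% and compound 3 gives 50%, so compound 3 stands second highest of the three, below compound 1 and above compound 2. The measured steps were a number 57 percentage points lower from compound 1 to compound 2 (beyond the scatter), a number 23 percentage points lower from compound 1 to compound 3 (beyond the scatter) and a number 34 percentage points higher from compound 2 to compound 3 (beyond the scatter).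

Compound 4 `NCC(O)Cn1c(=O)n(C2OC(CO)[C@@H](O)[C@H]2O)c2nc(N)nc(O)c21` differs from compound 3 by 2-amino-1-hydroxyethyl in place of 4-cyanophenyl on a saturated chain carbon bound to an aromatic nitrogen. All three measured steps change the group at this same place, and each moved the maximal response beyond the scatter, two of them by a large amount, so this place is sensitive. None of them, however, replaces the ring with an open chain carrying hydroxyl and amino groups, so the direction for compound 4 is not fixed by the data. Both measured moves away from compound 1 lowered the value, and the present change is the largest in what it removes and adds. A drop is therefore expected, and the step from compound 3 to compound 4 is estimated as a number 20 percentage points lower from compound 3 to compound 4 (beyond the scatter). For compound 4 the expected maximal response is 30%, with a range from 5% to 65%.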

Compound 4, largest response reached (reported as maximal response), in percent of the reference or control that the assay uses: 110%
Compound 4: the middle estimate sits 80 percentage points below what was measured, outside the stated range (above it).
By their numbers in this assay, from the lowest: compound 2; then compound 3; then compound 1; then compound 4.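

In this assay, the 2-amino-1-hydroxyethyl group on a saturated chain carbon bound to an aromatic nitrogen gives a rise against all three earlier groups: a number 60 percentage points higher from compound 3 to compound 4 (beyond the scatter), a number 94 percentage points higher from compound 2 to compound 4 (beyond the scatter) and a number 37 percentage points higher from compound 1 to compound 4 (beyond the scatter). Every earlier step at this place compared groups carrying an aromatic ring, whereas this change shows that, among these four compounds, an open chain with no ring gives the highest maximal response, so a ring at this place is not required for a large response. The available data hold no measurement that accounts for this rise.

The hydroxyl and the amine enter together in the single change from 4-cyanobenzyl to 3-amino-2-hydroxypropyl, so the compounds shown leave open which of the two, if either alone, goes with the higher value. A plain propyl chain, a 3-aminopropyl chain, a 2,3-dihydroxypropyl chain and a chain ending in a carboxylic acid in place of the amine would each separate these contributions, and a longer amino alcohol chain would test how much chain length matters.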